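Phenyl for methyl on the oxazole carbon of compound 3

A few compounds are considered here, and "the series" means these few. Any claim that something is new, unique, unknown or untested is made for them only; others in the source may bear on it.

Compound 3 `Cc1coc(C(=O)CCCCCCc2ccccc2)n1` is the weakest of the three measured compounds. In an assay on HEK-293T cells for inhibition of diacylglycerol lipase-alpha (Homo sapiens), read by colorimetric assay (on this read-out higher numbers stand for weaker inhibition and lower numbers for stronger inhibition), compound 3 gives only a limit, > 10000 nM. Compound 1 `CC(=O)c1coc(C(=O)CCCCCCc2ccccc2)n1` gives 123 nM, and compound 2 `CC(C)(C)C(=O)c1coc(C(=O)CCCCCCc2ccccc2)n1` gives 479 nM. The measured steps are a 3.9-fold higher number from compound 1 to compound 2 (0.59 log units; beyond the scatter), an at least 81-fold higher number from compound 1 to compound 3 (1.91 log units; beyond the scatter) and an at least 20-fold higher number from compound 2 to compound 3 (1.31 log units; beyond the scatter), so loss of the carbonyl-bearing group at this position carries the large losses, while the size of the group on the carbonyl carbon matters less.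

Compound 4 `O=C(CCCCCCc1ccccc1)c1nc(-c2ccccc2)co1` differs from compound 3 by phenyl in place of methyl on an aromatic carbon. Within the data shown here, no measured step covers phenyl in place of methyl at this carbon; the steps from compound 1 and compound 2 to compound 3 show only that a carbonyl group there is worth much, and phenyl brings none. A change of modest size in this assay, in either direction, is therefore expected, and the value for compound 4 is expected to be 8000 nM (range 1500 nM to 40000 nM), with the step of an at least 1.2-fold lower number from compound 3 to compound 4 (0.09 log units; that floor lies within the scatter) as the estimate, and a real chance of another limit.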

Compound 4, half-maximal inhibitory concentration: 8710 nM
The estimate for compound 4 lay 1.1-fold (0.04 log units) below the measured number; the measured number falls inside the stated range.
By their numbers in this assay, from the lowest: compound 1; then compound 2; then compound 4. At a limit, above all of these: compound 3.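

Phenyl at this carbon does not stand in for a carbonyl-bearing group, even though it brings more heavy atoms than methyl: replacing (tert-butyl)carbonyl gives an 18-fold higher number from compound 2 to compound 4 (1.26 log units; beyond the scatter), and replacing acetyl gives a 71-fold higher number from compound 1 to compound 4 (1.85 log units; beyond the scatter). Going from methyl to phenyl gives only an at least 1.1-fold lower number from compound 3 to compound 4 (0.05 log units; that floor lies within the scatter), so this change shows no gain that can be told from the scatter. That step can be stated only as a floor because compound 3 stands at a limit: the limit of > 10000 nM in this assay, at which 1 of the 4 values shown sits.

The compounds shown leave open whether another carbonyl-bearing group at this carbon, such as an amide or a carboxylic acid, would keep the stronger inhibition seen with acetyl. They also leave open how a shorter or longer chain on the other carbonyl would change these numbers.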